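The source may hold more compounds than are shown below. What is called first, only, known or untested is meant among the compounds shown, and "the series" means these compounds.

Measured in a toxicity assay on CHO-K1 cells (Cricetulus griseus) for cytotoxicity, read by MTT assay, with a stated time of 48 h; a higher number here means a weaker inhibitor, a lower number a stronger inhibitor:
- compound 1 `COc1cc(/C=C/C2=CC(=O)CC(c3ccc(O)c(OC)c3)N2CCCO)ccc1O`: > 100000 nM
- compound 2 `O=C(/C=C(/C=C/c1ccc(O)cc1)NCCCO)/C=C/c1ccc(O)cc1`: 39100 nM
- compound 3 `COCCNC(=C\C(=O)/C=C/c1ccc(O)cc1)/C=C/c1ccc(O)cc1`: 34900 nM

The result for compound 1 is a limit and not a number.

Going by the values given here, only two numbers are therefore available, and compound 3, at 34900 nM, lies within the scatter of compound 2, at 39100 nM.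

Next is compound 4 `O=C(/C=C(/C=C/c1ccc(O)cc1)NCCO)/C=C/c1ccc(O)cc1`. The change is hydrogen in place of methyl on an oxygen on a saturated carbon, which turns 2-methoxyethyl into 2-hydroxyethyl.

Among the compounds with values here, one measured step bears on this: a 1.1-fold lower number from compound 2 to compound 3 (0.05 log units; within the scatter), for methoxy in place of hydroxymethyl on a saturated chain carbon. That single step on the same chain stayed within the scatter, so no step beyond the scatter is expected in this assay, and no direction is favoured.

The estimated step is a 1.1-fold higher number from compound 3 to compound 4 (0.03 log units; within the scatter), which is expected to be indistinguishable from no change. For compound 4 the estimate is 37000 nM, with an expected range of 19000 nM to 72000 nM.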

Compound 4, half-maximal inhibitory concentration: 66000 nM
For compound 4 the middle estimate is 1.8-fold (0.25 log units) below the measured one; measured number inside the range.
By their numbers in this assay, from the lowest: compounds 3, 2 and 4 (each within the scatter of the next). At a limit, above all of these: compound 1.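

In this assay, hydrogen in place of methyl on the oxygen, which turns 2-methoxyethyl into 2-hydroxyethyl, gives a 1.9-fold higher number from compound 3 to compound 4 (0.28 log units; within the scatter). Hydroxy in place of hydroxymethyl on a saturated chain carbon gives a 1.7-fold higher number from compound 2 to compound 4 (0.23 log units; within the scatter), so a second kind of change on this chain now stands beside the earlier one. Neither step leaves the scatter, so this assay does not yet separate the hydroxy and methoxy chain ends or the two hydroxy-bearing chains.

Compound 1 remains a limit and not a number, and the readable range of the series ends there: the limit of > 100000 nM in this assay, at which 1 of the 4 values shown sits. Open, from the compounds shown here alone, is whether an amine or a carboxylic acid at the chain end, or a longer chain, would give a step beyond the scatter.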